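The source may report more compounds than this note shows. Statements on the series, on what has been measured and on what is new or still open speak of the compounds shown alone.

Among the measured compounds shown here, compound 1 `COc1cc(OC)c(OC)cc1/C=C/C(=O)c1ccccc1` is one of two compounds measured in a functional assay, read by Griess assay, with a stated time of 2.5 h; on this read-out lower numbers stand for stronger inhibition and higher numbers for weaker inhibition; compound 1 gives 2.01 ug/mL, the lowest of the two numbers so far, while compound 2 `COc1cc(OC)c(OC)cc1/C=C/C(=O)c1cccc([N+](=O)[O-])c1` gives 2.35 ug/mL. For the measured compounds named here, the single measured step, a 1.2-fold higher number from compound 1 to compound 2 (0.07 log units; within the scatter), was also a nitro in place of hydrogen on an aromatic carbon. Compound 3 `COc1cc(OC)c(OC)cc1/C=C/C(=O)c1ccc([N+](=O)[O-])cc1` differs from compound 1 by nitro in place of hydrogen on an aromatic carbon, a change of the same kind at a different place. Because the earlier step stayed within the scatter a 1.2-fold higher number from compound 1 to compound 2 (0.07 log units; within the scatter), no step beyond the scatter is expected for a 1.1-fold higher number from compound 1 to compound 3 (0.06 log units; within the scatter). Compound 3 is therefore estimated at 2.3 ug/mL, within 1 ug/mL to 5 ug/mL.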

Compound 3, half-maximal inhibitory concentration: 1.98 ug/mL
Estimate against measurement, compound 3: 1.2-fold (0.07 log units) above; low and high end bracket the measured number.
By their numbers in this assay, from the lowest: compounds 3, 1 and 2 (each within the scatter of the next).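

In this assay nitro in place of hydrogen on the aromatic carbon para to a large group gives a 1.0-fold lower number from compound 1 to compound 3 (0.01 log units; within the scatter) and this matches a 1.2-fold higher number from compound 1 to compound 2 (0.07 log units; within the scatter) at the other place on that ring. Nitro at either of two places on this ring thus produces no step beyond the scatter. Nothing shown here explains this result. On these data alone, whether an amine or a carboxylic acid at the same position would also stay within the scatter remains open. So does the effect of replacing the methoxy groups on the core of compound 1 with longer chains.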